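This account rests on a few compounds, and the source may have more. Where it says the series, first, only, none or still open, it means among the compounds named here.

Working notes on the series. Compound 1 `Cc1cc(NC(=O)c2cccc(C(F)(F)F)c2)ccc1NS(C)(=O)=O` is the reference point; in an ADME assay on RAW264.7 cells (Mus musculus) for cytotoxicity, read by MTT assay, with a stated time of 48 h (on this read-out higher numbers stand for weaker inhibition and lower numbers for stronger inhibition), compound 1 gives 110000 nM. Compound 2 `Cc1cc(NC(=O)c2cc(C(F)(F)F)cc(C(F)(F)F)c2)ccc1NS(C)(=O)=O` differs from it in one place: trifluoromethyl in place of hydrogen on an aromatic carbon. For compound 2 the read-out in this assay is a limit of the assay, > 250000 nM. The step of an at least 2.2-fold higher number from compound 1 to compound 2 (0.35 log units; beyond the scatter) is therefore set against the limit of > 250000 nM in this assay, at which 1 of the 3 values shown sits, and its full size is not known. Compound 3 `O=C(Nc1ccc(NS(=O)(=O)C(F)(F)F)c(F)c1)c1cccc(C(F)(F)F)c1` has a different core; the difference between the core of compound 3 and the core of compound 1 is not broken down here. In this assay compound 3 gives 34400 nM, the lowest of the two numbers recorded. Compound 4 `O=C(Nc1ccc(NS(=O)(=O)C(F)(F)F)c(F)c1)c1cc(C(F)(F)F)cc(C(F)(F)F)c1` stands to compound 3 as compound 2 stands to compound 1, the change being (trifluoromethyl in place of hydrogen on an aromatic carbon), at a place described in the same words as the earlier one, so it is the same change. The expectation for compound 4 rests on that single measured step, which only gave a lower bound. Compound 4 is expected to move upward by a 2.6-fold higher number from compound 3 to compound 4 (0.42 log units; beyond the scatter). Compound 4 is estimated at 90000 nM, with a range from 40000 nM to 250000 nM.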

Compound 4, half-maximal inhibitory concentration: 112000 nM
For compound 4 the middle estimate is 1.2-fold (0.09 log units) below the measured one; low and high end bracket the measured number.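

Trifluoromethyl in place of hydrogen on an aromatic carbon gives, in this assay, a 3.3-fold higher number from compound 3 to compound 4 (0.51 log units; beyond the scatter). Set beside the earlier step, the direction carries over from one core to the other, but the sizes of the two steps cannot be compared: the same change on two cores in this assay, an at least 2.2-fold higher number (0.35 log units; beyond the scatter) from compound 1 to compound 2 and a 3.3-fold higher number (0.51 log units; beyond the scatter) from compound 3 to compound 4; the limit leaves it open whether they differ. Only two cores are shown and one of the two steps ends at a limit of the assay, so this is no general rule for the series and no proof of an equal step on both cores: the limit of > 250000 nM in this assay, at which 1 of the 4 values shown sits.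

The compounds shown leave open how a nitrile, an amine or a carboxylic acid would read in this assay at the place taken by the added trifluoromethyl. They also leave open how the separate parts of the difference between the core of compound 1 and the core of compound 3 bear on the read-out, since that difference is not broken down into single changes.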